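The source may report more compounds than this note shows. Statements on the series, on what has been measured and on what is new or still open speak of the compounds shown alone.

Measured compounds in an assay on isolated protein for inhibition of histone deacetylase 4 (Homo sapiens), read by chemiluminescence, with a stated time of 3 h; a lower number here means a stronger inhibitor, a higher number a weaker inhibitor:
- compound 1 `COc1ccc(-c2cnc(NC(=O)CCCCCCNC(=O)C(O)(O)C(F)(F)F)s2)cc1`: 2500000 nM
- compound 2 `O=C(CCCCCCNC(=O)C(O)(O)C(F)(F)F)Nc1ncc(-c2ccc(Br)cc2)s1`: 1700000 nM

Going by the values given here, both numbers are very high; in this assay compound 2 gives the lower of the two, but the only step between them, a 1.5-fold lower number from compound 1 to compound 2 (0.17 log units; within the scatter), leaves the two within the scatter of each other, so no order is read into them.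

Compound 3 `O=C(CCCCCCNC(=O)C(O)(O)C(F)(F)F)Nc1ncc(-c2ccc(O)cc2)s1` is not yet measured. Its difference from compound 2 is hydroxy in place of bromo on an aromatic carbon; cut one bond further out, this reads as 4-bromophenyl to 4-hydroxyphenyl, on the aromatic carbon para to a large group. Among the compounds with values here, the single measured step changes the same aromatic carbon, methoxy to bromo, and amounted to a 1.5-fold lower number from compound 1 to compound 2 (0.17 log units; within the scatter), within the scatter. Nothing measured here separates a hydroxy group from either a methoxy or a bromo group at this position, so the expectation for compound 3 in this assay is a step of about a 1.2-fold higher number from compound 2 to compound 3 (0.07 log units; within the scatter), that is, none beyond the scatter, with a wide range to cover the untested group.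

The estimated value for compound 3 in this assay is 2000000 nM, with a range from 600000 nM to 7000000 nM.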

Compound 3, half-maximal inhibitory concentration: 2300000 nM
Estimate against measurement, compound 3: 1.2-fold (0.06 log units) below; the measured number falls inside the stated range.
By their numbers in this assay, from the lowest: compounds 2, 3 and 1 (each within the scatter of the next).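

In this assay, the series now holds three groups on this aromatic carbon, and hydroxy brings a hydrogen-bond donor and acceptor where bromo has neither, yet a 1.4-fold higher number from compound 2 to compound 3 (0.13 log units; within the scatter) is the whole of that step. The closer pair tells the same story, since a 1.1-fold lower number from compound 1 to compound 3 (0.04 log units; within the scatter) shows that taking the methyl off the oxygen on the aromatic ring does not separate the free hydroxy from the methoxy group. Methoxy, bromo and hydroxy therefore read alike at this position in these three compounds, all at very high numbers, and no information on the mechanism accompanies this reading.

Still open, on these data alone, is whether any group on this carbon can move the number beyond the scatter, for example an amine or a carboxylic acid in place of the hydroxy group. Also open, as far as these compounds go, is whether this flat reading belongs to the position itself or to the very high numbers shared by all three compounds, which a longer chain in place of the present one, with the 4-substituted phenyl kept, could begin to separate.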